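This account rests on a few compounds, and the source may have more. Where it says the series, first, only, none or still open, it means among the compounds named here.

Measured in an ADME assay on SH-SY5Y cells (Homo sapiens) for cytotoxicity, read by MTT assay, with a stated time of 72 h; on this read-out higher numbers stand for weaker inhibition and lower numbers for stronger inhibition:
- compound 1 `O=C(CN1CCN(C(=O)c2cccc(Br)c2)CC1)N1CCN(CCCc2c[nH]c3ccc(F)cc23)CC1`: 71600 nM
- compound 2 `COc1ccc2[nH]cc(CCCN3CCN(C(=O)CN4CCN(C(=O)c5ccc(Br)cc5)CC4)CC3)c2c1`: 150000 nM
- compound 3 `COc1cccc(C(=O)N2CCN(CC(=O)N3CCN(CCCc4c[nH]c5ccc(OC)cc45)CC3)CC2)c1`: > 200000 nM (a limit, not a number)

Compound 3 has no number and stands only at the limit of > 200000 nM in this assay, at which 1 of the 3 values shown sits. Compound 4 `COc1ccc2[nH]cc(CCCN3CCN(C(=O)CN4CCN(C(=O)c5cccc(Br)c5)CC4)CC3)c2c1` differs from it by bromo in place of methoxy on an aromatic carbon, with 3-bromophenyl in place of 3-methoxyphenyl. The closest measured step is an at least 1.3-fold higher number from compound 2 to compound 3 (0.12 log units; that floor lies within the scatter), which runs from a bromophenyl to the same 3-methoxyphenyl but fixes no firm size. Compound 1, which also carries the 3-bromophenyl, gives 71600 nM. A small move to a lower number is therefore expected in this assay, possibly within the scatter. The estimated step is an at least 1.6-fold lower number from compound 3 to compound 4 (0.22 log units; that floor lies within the scatter). For compound 4 the expected value is 120000 nM, with an estimated range of 60000 nM to 200000 nM.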

Compound 4, half-maximal inhibitory concentration: 105000 nM
For compound 4 the middle estimate is 1.1-fold (0.06 log units) above the measured one, and the stated range covers the measured number.
By their numbers in this assay, from the lowest: compounds 1, 4 and 2 (each within the scatter of the next, the first and the last beyond it). At a limit, above all of these: compound 3.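

In this assay, bromo in place of methoxy on an aromatic carbon gives an at least 1.9-fold lower number from compound 3 to compound 4 (0.27 log units; that floor lies within the scatter). This floor rests on a limit for compound 3, not a number: the limit of > 200000 nM in this assay, at which 1 of the 4 values shown sits. The bromine's placement and the other aromatic substituent show no step beyond the scatter, with 3-bromophenyl in place of 4-bromophenyl giving a 1.4-fold lower number from compound 2 to compound 4 (0.15 log units; within the scatter) and methoxy in place of fluoro giving a 1.5-fold higher number from compound 1 to compound 4 (0.17 log units; within the scatter).

Still open, from the compounds shown here alone, is whether an amine or a carboxylic acid at this position would move the number beyond the scatter. Going by these compounds, a longer chain in place of methoxy is equally open.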